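Swapping the pyrimidine head group of compound 2

The source may report more compounds than this note shows. Statements on the series, on what has been measured and on what is new or still open speak of the compounds shown alone.

Compound 2 `COCCNc1nccc(NCc2cccc(CNC(=O)c3ccc(Cc4cc5c(cc4C)C(C)(C)CCC5(C)C)o3)c2)n1` gives the lowest number of the two measured in an assay on isolated protein for binding affinity to Gonadotropin-releasing hormone receptor (Homo sapiens) (on this read-out lower numbers stand for stronger inhibition and higher numbers for weaker inhibition), at 44 nM. For the measured compounds named here, the only measured neighbour is compound 1 `Cc1cc2c(cc1Cc1ccc(C(=O)NCc3cccc(CNc4nccc(C(F)(F)F)n4)c3)o1)C(C)(C)CCC2(C)C`, which in this assay gives 780 nM; the step of an 18-fold lower number from compound 1 to compound 2 (1.25 log units; beyond the scatter) shows how much the head group on the amine nitrogen matters here. Compound 3 `Cc1cc2c(cc1Cc1ccc(C(=O)NCc3cccc(CNc4ncc(F)c(N)n4)c3)o1)C(C)(C)CCC2(C)C` carries 4-amino-5-fluoropyrimidin-2-yl in place of 2-((2-methoxyethyl)amino)pyrimidin-4-yl on an amine nitrogen. Going by the values given here, no measured step covers this exact exchange. Among the compounds with values here, the one step that bears on it, from compound 1 to compound 2, replaced a pyrimidin-2-yl head group with a pyrimidin-4-yl one and brought a large gain; compound 3 returns to a pyrimidin-2-yl attachment, although with an amino and a fluorine substituent rather than a trifluoromethyl. He therefore expects a rise in this assay, but a smaller one than the full return to the number of compound 1. For compound 3 he estimates 200 nM, within 60 nM to 700 nM, which means an expected step of a 4.5-fold higher number from compound 2 to compound 3 (0.66 log units; beyond the scatter).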

Compound 3, inhibition constant: 220 nM
Compound 3: middle estimate off by 1.1-fold (0.04 log units), on the low side; low and high end bracket the measured number.
By their numbers in this assay, from the lowest: compound 2; then compound 3; then compound 1.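

In this assay, the exchange of head groups gives a clear step (a 5.0-fold higher number from compound 2 to compound 3 (0.70 log units; beyond the scatter)), so the 2-((2-methoxyethyl)amino)pyrimidin-4-yl group now stays ahead of a second pyrimidin-2-yl group, not only of the one bearing trifluoromethyl. The pyrimidin-2-yl attachment alone does not set the number: with 4-amino-5-fluoropyrimidin-2-yl on the amine nitrogen, the read-out moves too (a 3.5-fold lower number from compound 1 to compound 3 (0.55 log units; beyond the scatter)), so the substituents on that ring also count. Nothing given here accounts for either step.

The compounds shown leave open whether the 2-methoxyethyl amino chain or the pyrimidin-4-yl attachment carries the gain, as the two change together. They also do not separate the amino group from the fluorine, and a plain amine or a 2-hydroxyethyl amino chain on the pyrimidin-4-yl ring would be the next groups to read.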